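The source may report more compounds than this note shows. Statements on the series, on what has been measured and on what is new or still open speak of the compounds shown alone.

Measured in an ADME assay on Vero cells (Chlorocebus sabaeus) for cytotoxicity, read by MTT assay, with a stated time of 72 h; on this read-out lower numbers stand for higher toxicity in this test and higher numbers for lower toxicity in this test:
- compound 1 `C[C@]1(CN2CCc3nc(N4CCCCC4)ccc3C2)Cn2cc([N+](=O)[O-])nc2O1`: "not determined" (no result reported)
- compound 2 `C[C@]1(CN2CCc3nc(-c4ccc(F)c(Cl)c4)ccc3C2)Cn2cc([N+](=O)[O-])nc2O1`: > 32 ug/mL

Compound 2 sits at the limit of > 32 ug/mL in this assay, at which 1 of the 2 values shown sits, which is a limit and not a number. Among the measured compounds shown here, compound 1 offers no comparison, and the series holds no measured step. Compound 3 `C[C@]1(CN2CCc3nc(-c4cc(F)ccc4Cl)ccc3C2)Cn2cc([N+](=O)[O-])nc2O1` carries 2-chloro-5-fluorophenyl in place of 3-chloro-4-fluorophenyl on an aromatic carbon, next to the ring nitrogen (2-chloro-5-fluorophenyl in place of 3-chloro-4-fluorophenyl on an aromatic carbon). In this assay no change beyond the scatter is expected, in either direction, and the estimated step that the limit leaves unreadable from compound 2 to compound 3 is correspondingly small. A result reported again only as a limit is the likeliest outcome. For compound 3 the estimated value is 35 ug/mL, with an expected range of 16 ug/mL to 64 ug/mL.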

Compound 3, half-maximal cytotoxic concentration: > 32 ug/mL
Compound 3 gave a limit, no number (the forecaster's own chance of this, stated with the estimate: 80%); the middle value does not contradict the limit.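

In this assay, among the compounds shown here, compound 2 and compound 3 are both reported only as limits, not numbers, and no step between them can be read. The compounds shown leave open where either actual value lies, and whether 2-chloro-5-fluorophenyl in place of 3-chloro-4-fluorophenyl changes the read-out at all.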